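Acetamido in Place of Hydroxymethyl: Expected Inhibition

A few compounds are considered here, and "the series" means these few. Any claim that something is new, unique, unknown or untested is made for them only; others in the source may bear on it.

Measured so far:
Compound 1 `Oc1cccc(CNc2cc(Br)cc3[nH]ncc23)c1` — in an assay for inhibition of Indoleamine 2,3-dioxygenase 1 (Homo sapiens), with a stated time of 1 h, tested at 10 uM (on this read-out higher numbers stand for more inhibition at the one concentration tested (going by the name of the read-out) and lower numbers for less inhibition), compound 1 gives 45%.
Compound 2 `OCc1ccc(CNc2cc(Br)cc3[nH]ncc23)cc1` — in this assay compound 2 gives 45%.

Compound 2 stands level with compound 1 at the digits shown: the two values lie within the scatter of one another, so no order between them can be read from these numbers. For the measured compounds named here, both carry the same core, the one drawn for compound 1, and differ only in the group on the benzylic ring; no single-point step between measured compounds has been worked out here, so the two values are simply what each compound shows.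

Compound 3 `CC(=O)Nc1ccc(CNc2cc(Br)cc3[nH]ncc23)cc1` has not yet been measured in this assay. It differs from compound 2 as follows: acetamido in place of hydroxymethyl on an aromatic carbon. Acetamido, like hydroxymethyl, brings one hydrogen-bond donor and one acceptor, so a small step in this assay is expected, in either direction, most likely none beyond the scatter. For compound 3 the expected value is 42%, with a range from 25% to 60%, which amounts to an expected step of a number 3 percentage points lower from compound 2 to compound 3 (within the scatter).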

Compound 3, a percentage reported as inhibition, at one concentration (the size of the read-out at that concentration, not a potency): 48%
Compound 3: middle estimate off by 6 percentage points, on the low side; measured number inside the range.
By their numbers in this assay, from the lowest: compounds 1, 2 and 3 (each within the scatter of the next).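

In this assay, acetamido in place of hydroxymethyl on an aromatic carbon, para to a large group, comes to a number 3 percentage points higher from compound 2 to compound 3 (within the scatter), the first step read at this position. The group that enters has 4 heavy atoms against 2 for the one that leaves, and it adds a nitrogen and a double bond outside aromatic rings, yet the read-out does not separate the two compounds. Each group has 1 hydrogen-bond donor and 1 hydrogen-bond acceptor, so these compounds say nothing about a group at this position that differs in those counts, and no measurement shown here explains why the two groups read alike.

Still open, from the compounds shown here alone, is whether an amine, a carboxylic acid or a longer chain ending in a hydroxyl would read apart from these values at this position. Also open is whether acetamido would read the same at the ring place where compound 1 carries its hydroxyl, as no compound shown has that group there.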